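Stereochemical inversion at the ring carbon in a phosphoserine ester series

The source may hold more compounds than are shown below. What is called first, only, known or untested is meant among the compounds shown, and "the series" means these compounds.

Measured compounds:
compound 1 `COC[C@H](COC(=O)CCc1ccccc1OCc1cccc(Oc2ccccc2)c1)OP(=O)(O)OC[C@H](N)C(=O)O`, "not active" (no number reported)
compound 2 `CCOC[C@H](COC(=O)CCc1ccccc1OCc1cccc(Oc2ccccc2)c1)OP(=O)(O)OC[C@H](N)C(=O)O`, "not active" (no number reported)
compound 3 `CCCCCCCCCCCOc1ccccc1CCC(=O)O[C@H]1CCOC[C@H]1OP(=O)(O)OC[C@H](N)C(=O)O`, 3.2%

In an assay on HEK293 cells for agonist activity at putative P2Y purinoceptor 10 (Mus musculus), with a stated time of 1 h (a lower number here means a smaller maximal response, a higher number a larger maximal response), compound 1 gives "not active" (no number reported). In this assay compound 2 gives "not active" (no number reported). In this assay compound 3 gives 3.2%, the only numerical read-out in the set; the two other entries carry no number. Compound 3 thus stands as a near-silent entry on the numbers shown.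

Compound 4 `CCCCCCCCCCCOc1ccccc1CCC(=O)O[C@H]1CCOC[C@@H]1OP(=O)(O)OC[C@H](N)C(=O)O` differs from compound 3 as follows: the two compounds have the same atoms and bonds; at least one stereo element is drawn with a configuration in one of them and without one in the other: 1 of 4 stereo elements differ; a stereocentre at a saturated ring carbon is drawn R in compound 3 and S in compound 4

Going by the values given here, no measured pair differing in one place is available, so no step size is known. Given the maximal response of compound 3 at 3.2%, compound 4 is expected to sit at a similar level, with the step of a number 1.8 percentage points higher from compound 3 to compound 4 (within the scatter) estimated as none beyond the scatter. Compound 4 is estimated at 5%, within 0% to 15%.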

Compound 4, largest response reached (Emax), in percent of the reference or control that the assay uses: 11.1%
Estimate against measurement, compound 4: 6.1 percentage points below; measured number inside the range.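

Inverting the stereocentre at the saturated ring carbon gives the series its first measurable step in this assay: a number 7.9 percentage points higher from compound 3 to compound 4 (within the scatter). On these numbers, the maximal response does not separate the two drawn configurations at this position. The reading of this pair carries a caveat: the fact that one of compounds 3 and 4 is drawn with a defined configuration and the other without, at the place where they differ

Open, as far as these compounds go, is whether a longer chain in place of the ether tail would separate the two configurations beyond the scatter. Also open, from the compounds shown here alone, is whether a primary amine on the shared core would do so.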